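The source may report more compounds than this note shows. Statements on the series, on what has been measured and on what is new or still open speak of the compounds shown alone.

Measured so far in an ADME assay on PC-3 cells (Homo sapiens) for cytotoxicity, read by WST assay, tested at 100 uM; on this read-out lower numbers stand for less inhibition and higher numbers for more inhibition at the one concentration tested (going by the name of the read-out):
compound 1 `Cc1nc(-c2cccc(C(=O)N3CCCC(C(=O)Nc4ccc(Cl)cc4)C3)c2)no1` gives 0%
compound 2 `CS(=O)(=O)Nc1cccc(C(=O)N2CCCC(C(=O)Nc3ccc(Cl)cc3)C2)c1` gives 3%
compound 3 `N#Cc1cccc(C(=O)N2CCCC(C(=O)Nc3ccc(Cl)cc3)C2)c1` gives 0%

Compound 3 stands level with compound 1 and together with it at the low end of the three numbers; the step of no change at the digits printed from compound 1 to compound 3 (within the scatter) lies within the scatter, as does a number 3 percentage points lower from compound 2 to compound 3 (within the scatter) and a number 3 percentage points higher from compound 1 to compound 2 (within the scatter). All three exchanges of the group on the aromatic carbon have left this assay flat.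

Compound 4 `COCc1cccc(C(=O)N2CCCC(C(=O)Nc3ccc(Cl)cc3)C2)c1` differs from compound 3 as follows: methoxymethyl in place of cyano on an aromatic carbon. Every measured step touching this position stayed within the scatter, so no step beyond the scatter is expected here either; a number 2 percentage points higher from compound 3 to compound 4 (within the scatter) is the estimated change. Compound 4 is expected to give 2% in this assay, with a range from 0% to 10%.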

Compound 4, a percentage reported as inhibition, at one concentration (the size of the read-out at that concentration, not a potency): 0%
For compound 4 the middle estimate is 2 percentage points above the measured one, and the stated range covers the measured number.
By their numbers in this assay, from the lowest: compounds 1, 3, 4 and 2 (each within the scatter of the next).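

Methoxymethyl on this aromatic carbon, in place of cyano, leaves this assay flat (no change at the digits printed from compound 3 to compound 4 (within the scatter)), and the same holds against the other two groups (a number 3 percentage points lower from compound 2 to compound 4 (within the scatter); no change at the digits printed from compound 1 to compound 4 (within the scatter)). This extends the flat reading to a group with no ring and no triple bond, so all four groups shown at this position now lie within the scatter of one another. No measurement at hand gives a cause for this flat reading.

As far as these compounds go, whether an amine, a carboxylic acid or a longer chain at this carbon would give a step beyond the scatter stays open.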